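This account rests on a few compounds, and the source may have more. Where it says the series, first, only, none or still open, it means among the compounds named here.

In an ADME assay on HEK-293T cells (Homo sapiens) for cytotoxicity, read by CCK-8 assay, with a stated time of 48 h (on this read-out higher numbers stand for weaker inhibition and lower numbers for stronger inhibition), compound 1 `COc1ccc(NC(=O)NCCNS(=O)(=O)c2ccc(-c3ccccc3OCc3ccccc3)s2)cc1` gives > 50000 nM, which is a limit. Compound 2 `Cc1cc(C)cc(NC(=O)NCCNS(=O)(=O)c2ccc(-c3ccccc3OCc3ccccc3)s2)c1` gives > 20000 nM, also a limit, so it stands on no readable number. Going on to compound 3 `O=S(=O)(NCCNC(=S)Nc1ccc(Cl)cc1)c1ccc(-c2ccccc2OCc2ccccc2)s1` makes this change on an amine nitrogen: a group of 10 heavy atoms (7 carbon, 1 nitrogen, 1 sulfur, 1 chlorine; one six-membered aromatic ring of carbon only) in place of a group of 11 heavy atoms (9 carbon, 1 nitrogen, 1 oxygen; one six-membered aromatic ring of carbon only), on an amine nitrogen. Among the compounds with values here, the only measured step that bears on it is a step that the two limits leave unreadable from compound 1 to compound 2, so no size can be carried over. No step beyond the scatter is expected in this assay, and the estimated step is a step that the limit leaves unreadable from compound 2 to compound 3. For compound 3 the expected value is 25000 nM, with an estimated range of 10000 nM to 60000 nM.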

Compound 3, half-maximal inhibitory concentration: 12100 nM
For compound 3 the middle estimate is 2.1-fold (0.32 log units) above the measured one; measured number inside the range.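

In this assay, within the data shown here, compound 3 gives 12100 nM, the first readable number for a group on this amine nitrogen. Against the (3,5-dimethylphenyl)carbamoyl group, the group holding sulfur and chlorine gives an at least 1.6-fold lower number from compound 2 to compound 3 (0.21 log units; that floor lies within the scatter), while the comparison with the 4-methoxyphenyl compound gives an at least 4.1-fold lower number from compound 1 to compound 3 (0.61 log units; beyond the scatter). That second step is only a floor, set by a limit: the limit of > 50000 nM in this assay, at which 1 of the 3 values shown sits.

Sulfur and chlorine enter together, so the share of each in the step stays open. On these data alone, how a carboxylic acid or an amine on the aromatic ring would read also stays open.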